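Amide-tail replacement in a shared-core cytotoxicity series

The source may hold more compounds than are shown below. What is called first, only, known or untested is meant among the compounds shown, and "the series" means these compounds.

Measured so far:
Compound 1 `Cn1c(-c2ccc(NC(=O)CCl)cc2)nc(-c2ccccc2)c1-c1ccccc1` gives 42.8% in a functional assay on MCF7 cells (Homo sapiens) for cytotoxicity, read by MTT assay, with a stated time of 24 h, tested at 32 ug/mL; on this read-out higher numbers stand for a stronger effect at the one concentration tested and lower numbers for a weaker effect.
Compound 2 `Cn1c(-c2ccc(NC(=O)CSc3nc4ccccc4o3)cc2)nc(-c2ccccc2)c1-c1ccccc1` gives 71.5%.
Compound 3 `Cn1nnnc1SCC(=O)Nc1ccc(-c2nc(-c3ccccc3)c(-c3ccccc3)n2C)cc1` gives 77.5%.

Compound 3 stands highest of the three numbers, though its gap to compound 2 is within the scatter; only its gap to compound 1 is beyond it. The two steps that moved the numbers were a number 28.7 percentage points higher from compound 1 to compound 2 (beyond the scatter) and a number 34.7 percentage points higher from compound 1 to compound 3 (beyond the scatter), both replacing a chloro on the chain carbon with a heteroaryl sulfanyl group, while a number 6 percentage points higher from compound 2 to compound 3 (within the scatter) shows that swapping one heteroaryl for the other changed nothing.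

Compound 4 `CCN1CCN(CC(=O)Nc2ccc(-c3nc(-c4ccccc4)c(-c4ccccc4)n3C)cc2)CC1` differs from compound 3 in that (4-ethylpiperazin-1-yl in place of (1-methyl-1H-tetrazol-5-yl)sulfanyl on a saturated chain carbon bound to a carbonyl carbon). Going by the values given here, no measured step covers this kind of change: every group compared so far sat on a sulfur or was a chloro. The shared core with a substituted acetamide has given numbers across the full measured span, so compound 4 may fall anywhere in it. Compound 4 is expected to give about 55%, within 30% to 80%. This estimate is expected to amount to a number 22.5 percentage points lower from compound 3 to compound 4 (beyond the scatter).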

Compound 4, a percentage reported as activity, at one concentration (the size of the read-out at that concentration, not a potency): 38.6%
The estimate for compound 4 lay 16.4 percentage points above the measured number, and the stated range covers the measured number.
By their numbers in this assay, from the lowest: compounds 4 and 1 (each within the scatter of the next); then compounds 2 and 3 (each within the scatter of the next).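

In this assay, this saturated chain carbon bound to a carbonyl carbon proved sensitive to more than the presence of a ring: 4-ethylpiperazin-1-yl gave a number 38.9 percentage points lower from compound 3 to compound 4 (beyond the scatter) and a number 32.9 percentage points lower from compound 2 to compound 4 (beyond the scatter), so the high numbers of the two sulfanyl compounds did not carry over to this group. Measured against chloro, the same replacement gave a number 4.2 percentage points lower from compound 1 to compound 4 (within the scatter), so a ring at this place did not by itself raise the number. Nothing measured here explains the fall with this change. Going by these compounds, whether the fall comes from losing the sulfur or from the 4-ethylpiperazin-1-yl ring itself stays open. Also open, on these data alone, is how a morpholine, a dimethylamino group or a phenylsulfanyl group would read at this place.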